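The compounds below may be only part of what the source reports. "The series", "measured", "known", "first", "only" and "open" are said of these compounds alone.

Measured in a toxicity assay on MCF-10A cells (Homo sapiens) for inhibition, read by MTT assay, with a stated time of 48 h; on this read-out higher numbers stand for weaker inhibition and lower numbers for stronger inhibition:
- Compound 1 `Cn1c(/C=C2\SC(=O)N(CC(=O)Nc3cc(C(C)(C)C)on3)C2=O)nc2ccccc21`: 38700 nM
- Compound 2 `Cn1c(/C=C2\SC(=O)N(CC(=O)Nc3nc(-c4ccccc4)cs3)C2=O)nc2ccccc21`: > 100000 nM (a limit, not a number)
- Compound 3 `COc1cc2c(cc1OC)CN(C(=O)CN1C(=O)S/C(=C\c3nc4ccccc4n3C(C)C)C1=O)CC2`: > 100000 nM (a limit, not a number)

Compound 3 has no exact value, only the limit > 100000 nM. The data are thin, with most of them sitting at the limit of > 100000 nM in this assay, at which 2 of the 3 values shown sit. Compound 4 `COc1cc2c(cc1OC)CN(C(=O)CN1C(=O)S/C(=C\c3nc4ccccc4n3C)C1=O)CC2` differs from compound 3 by one change, methyl in place of isopropyl on an aromatic nitrogen. For the measured compounds named here, no measured step covers this change. The only one, an at least 2.5-fold higher number from compound 1 to compound 2 (0.41 log units; beyond the scatter), lies on an amide-type nitrogen elsewhere in the molecule, so it bears only loosely, showing a modest move at the least. The 1-methyl-1H-benzimidazol-2-yl group of compound 4 also occurs in compound 1, which gives 38700 nM. Compound 2 carries that group too and reaches only the limit > 100000 nM. A small shift towards stronger inhibition is possible, but another result at the limit is about as plausible. The expected change is small, an at least 1.1-fold lower number from compound 3 to compound 4 (0.04 log units; that floor lies within the scatter). Compound 4 is expected at about 90000 nM, with an estimated range of 35000 nM to 200000 nM.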

Compound 4, half-maximal inhibitory concentration: > 100000 nM
Compound 4: no number, only a limit; the forecaster's own chance of this, stated with the estimate: 65%; at least 1.1-fold (0.04 log units) between middle value and limit.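

Compound 3 and compound 4 each give only a limit, not a number, so no step can be read between them: the limit of > 100000 nM in this assay, at which 3 of the 4 values shown sit.

The compounds shown leave open whether methyl in place of isopropyl on the aromatic nitrogen changes the result at all in this assay.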